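This account rests on a few compounds, and the source may have more. Where it says the series, first, only, none or still open, it means among the compounds named here.

Measured compounds in an ADME assay on RAW264.7 cells (Mus musculus) for cytotoxicity, read by MTT assay, with a stated time of 24 h; a lower number here means that less compound is tolerated, a higher number that more compound is tolerated:
- compound 1, `O=C1CSC(N2N=C(c3ccc(Cl)c(Cl)c3)CC2c2ccc(Cl)cc2)=N1`: 187000 nM
- compound 2, `Cc1ccc(C2=NN(C3=NC(=O)CS3)C(c3ccc(Cl)cc3)C2)cc1C`: 226000 nM
- compound 3, `Cc1ccc(C2=NN(C3=NC(=O)CS3)C(c3ccccc3)C2)cc1C`: > 450000 nM, a limit of the assay and not a number

Compound 1 holds the lowest of the two numbers given; its nearest neighbour is compound 2, and the step of a 1.2-fold higher number from compound 1 to compound 2 (0.08 log units; within the scatter) lies within the scatter, so no order between the two can be read. Compound 3 sits at the limit of > 450000 nM in this assay, at which 1 of the 3 values shown sits. The step of an at least 1.9-fold higher number from compound 2 to compound 3 (0.29 log units; that floor lies within the scatter) has a floor that also lies within the scatter.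

Compound 4, `Cc1cccc(C2CC(c3ccc(Cl)c(Cl)c3)=NN2C2=NC(=O)CS2)c1`, has not been measured in this assay. Against compound 1 the change is 3-methylphenyl in place of 4-chlorophenyl on a saturated ring carbon. Going by the values given here, no measured step repeats this exact change. The nearest guide is the step from compound 2 to compound 3, where a chloro on an aromatic carbon was replaced by hydrogen and the number rose no further than the scatter allows; the step from compound 1 to compound 2, which swapped one aryl group for another, also stayed within the scatter. On this basis no step beyond the scatter is expected, with at most a drift toward a higher number.

Compound 4 is expected to give 250000 nM, in the range 120000 nM to 500000 nM. The expected step is a 1.3-fold higher number from compound 1 to compound 4 (0.13 log units; within the scatter).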

Compound 4, half-maximal cytotoxic concentration: 204000 nM
Estimate against measurement, compound 4: 1.2-fold (0.09 log units) above; the measured number falls inside the stated range.
By their numbers in this assay, from the lowest: compounds 1, 4 and 2 (each within the scatter of the next). At a limit, above all of these: compound 3.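

In this assay, 3-methylphenyl in place of 4-chlorophenyl on the saturated ring carbon gives a 1.1-fold higher number from compound 1 to compound 4 (0.04 log units; within the scatter), so this carbon takes the exchange of one substituted aryl group for another without a step beyond the scatter, here with the 3,4-dichlorophenyl group held constant. Going by these compounds alone, this is the first change at this carbon with a number at both ends, since the earlier change here, from compound 2 to compound 3, ends in a limit of the assay and not a number. No measurement shown bears on why the new step stays within the scatter.

Open, going by these compounds, is whether the series keeps numbers of this size in this assay when the aryl group on this carbon carries an amine or a carboxylic acid, or gives way to a longer alkyl chain. On these data alone, the true size of the step from compound 2 to compound 3 also remains open, so the effect of the chloro alone on this aryl group cannot be set beside the new step.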